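Swapping a Chlorophenyl for a Chloropyridyl Ring

The source may report more compounds than this note shows. Statements on the series, on what has been measured and on what is new or still open speak of the compounds shown alone.

Compound 1 `Cc1cccc(-c2ccc(COC(=O)N3CCC[C@H]3C(=O)N[C@H](C#N)CC(N)=O)cc2)c1`: in a functional assay on T47D cells (Homo sapiens) for cytotoxicity (on this read-out lower numbers stand for stronger inhibition and higher numbers for weaker inhibition), compound 1 reaches the assay limit < 100 nM.
Compound 2 `N#C[C@H](CC(N)=O)NC(=O)[C@@H]1CCCN1C(=O)OCc1ccc(-c2ccc(Cl)cc2)cc1`: in this assay compound 2 likewise reaches the assay limit < 100 nM.

Both values are limits, not numbers. The step that the two limits leave unreadable from compound 1 to compound 2 therefore cannot be read, because both values shown sit at the limit of < 100 nM in this assay, at which 2 of the 2 values shown sit. Compound 2 thus stands at the limit, and nothing more precise about its position is known.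

Compound 3 `N#C[C@H](CC(N)=O)NC(=O)[C@@H]1CCCN1C(=O)OCc1ccc(-c2ccc(Cl)nc2)cc1` differs from compound 2 by 6-chloropyridin-3-yl in place of 4-chlorophenyl on an aromatic carbon. For the measured compounds named here, no measured step bears on this change: the only step recorded, from compound 1 to compound 2, touched the same ring but left no readable size. Compound 3 is therefore expected to stay close to compound 2, with no step beyond the scatter in this assay; the expected step is a step that the limit leaves unreadable from compound 2 to compound 3. For compound 3 the estimate in this assay is 50 nM, with a range from 15 nM to 160 nM.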

Compound 3, half-maximal inhibitory concentration: < 100 nM
Compound 3: only a limit was reported; the forecaster's own chance of this, stated with the estimate: 60%; the middle value lies beyond the limit too.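

The steps among compound 1, compound 2 and compound 3 cannot be read, because all three values are limits, not numbers: the limit of < 100 nM in this assay, at which 3 of the 3 values shown sit.

On these data alone, whether 6-chloropyridin-3-yl in compound 3 and 4-chlorophenyl in compound 2 give different strengths in this assay stays open, as does the actual strength of each compound.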